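The compounds below may be only part of what the source reports. "The series", "measured", "known", "first", "only" and "open" are said of these compounds alone.

Compound 1 `CC(C)c1ccc(C(=O)/C=C/C(=O)O)cc1`: 5560 nM
Compound 2 `CCCCc1ccc(C(=O)/C=C/C(=O)O)cc1`: 4950 nM

In a functional assay on K562 cells (Homo sapiens) for inhibition, read by MTT assay, with a stated time of 72 h (on this read-out higher numbers stand for weaker inhibition and lower numbers for stronger inhibition), compound 2 stands level with compound 1, within the scatter. Compound 3 `O=C(O)/C=C/C(=O)c1ccc(F)cc1` has not yet been measured. It carries fluoro in place of butyl on an aromatic carbon. For the measured compounds named here, the only measured step is a 1.1-fold lower number from compound 1 to compound 2 (0.05 log units; within the scatter), within the scatter, and it replaces isopropyl with butyl. Going by the values given here, no measured compound carries fluoro, so this step is only a weak guide. The expected change is a 1.2-fold higher number from compound 2 to compound 3 (0.08 log units; within the scatter), which means no shift beyond the scatter is expected. For compound 3 the estimated value is 6000 nM, with an expected range from 2500 nM to 14000 nM.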

Compound 3, half-maximal inhibitory concentration: 16900 nM
Compound 3: the middle estimate sits 2.8-fold (0.45 log units) below what was measured; the measured number lies above the stated range.
By their numbers in this assay, from the lowest: compounds 2 and 1 (each within the scatter of the next); then compound 3.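

In this assay, the place on the aromatic carbon, para to a group of 7 heavy atoms, now proves responsive to the group it carries: fluoro in place of butyl gives a clear change (a 3.4-fold higher number from compound 2 to compound 3 (0.53 log units; beyond the scatter)), and fluoro in place of isopropyl gives one of like kind (a 3.0-fold higher number from compound 1 to compound 3 (0.48 log units; beyond the scatter)). Butyl and isopropyl had stood level, so only the exchange to fluoro has moved the number beyond the scatter. Nothing available speaks to the reason for this. Going by these compounds, whether a methyl or a chlorine at this place would side with fluoro or with butyl stays open. So does the outcome for an amine or a hydroxyl there.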